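Tetrazole methylene insertion in a quinoline-ether series

The compounds below may be only part of what the source reports. "The series", "measured", "known", "first", "only" and "open" are said of these compounds alone.

Of the compounds shown here, three of one shared core have been measured in an assay on isolated protein for binding affinity to cysteinyl leukotriene receptor 1 (Cavia porcellus); on this read-out higher numbers stand for weaker inhibition and lower numbers for stronger inhibition. Compound 1 `c1cc(OCc2ccc(-c3nn[nH]n3)cc2)cc(OCc2ccc3ccccc3n2)c1` gives 10 nM. Compound 2 `c1cc(OCc2ccc3ccccc3n2)cc(OCc2ccccc2-c2nn[nH]n2)c1` gives 20 nM. Compound 3 `c1cc(OCc2ccc(Cc3nnn[nH]3)cc2)cc(OCc2ccc3ccccc3n2)c1` gives 7.3 nM. The step from compound 1 to compound 3 is (1H-tetrazol-5-yl)methyl in place of 2H-tetrazol-5-yl on an aromatic carbon, and it gave a 1.4-fold lower number from compound 1 to compound 3 (0.14 log units; within the scatter). Compound 2 and compound 1 share the same atoms joined differently; the difference between the two cores is not broken down here. Compound 2 shows the highest number of the three, within the scatter of compound 1 and beyond it against compound 3.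

Compound 4 `c1cc(OCc2ccc3ccccc3n2)cc(OCc2ccccc2Cc2nnn[nH]2)c1` is not yet measured. It differs from compound 2 by (1H-tetrazol-5-yl)methyl in place of 2H-tetrazol-5-yl on an aromatic carbon. This is the same kind of change as from compound 1 to compound 3, not the same: there the entering group sits para to a large group, here ortho to a large group.

In this assay the expected step is a 1.3-fold lower number from compound 2 to compound 4 (0.12 log units; within the scatter), resting on a 1.4-fold lower number from compound 1 to compound 3 (0.14 log units; within the scatter) and on the value of compound 2 20 nM. Compound 4 is estimated at 15 nM, with a range from 6 nM to 40 nM.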

Compound 4, inhibition constant: 12 nM
Compound 4: the middle estimate sits 1.3-fold (0.10 log units) above what was measured; measured number inside the range.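

In this assay, (1H-tetrazol-5-yl)methyl in place of 2H-tetrazol-5-yl gave a 1.7-fold lower number from compound 2 to compound 4 (0.22 log units; within the scatter), so with the entering group ortho to a large group the change again stays inside the scatter. Set beside the earlier step, the change reads alike on the core of compound 1 and the core of compound 2: the same change on two cores in this assay, a 1.4-fold lower number (0.14 log units; within the scatter) from compound 1 to compound 3 and a 1.7-fold lower number (0.22 log units; within the scatter) from compound 2 to compound 4, 1.2-fold (0.09 log units) apart, within the scatter of two such steps. Within the data shown here, with only two pairs, both within the scatter, this shows that the change left the number essentially unmoved on these two cores, but it does not show that the entering group truly lowers the number on either core, or that the agreement would hold on any further core.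

Open, from the compounds shown here alone, is whether a longer chain in front of the tetrazole, such as an ethylene link, or a carboxylic acid in its place, would keep the number in this range. Going by these compounds, all the numbers also come from this assay alone, so how the change reads on any other read-out remains open.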